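Bromo at the core of compound 1: an estimate

A few compounds are considered here, and "the series" means these few. Any claim that something is new, unique, unknown or untested is made for them only; others in the source may bear on it.

Among the compounds with values here, compound 1 `O=[N+]([O-])c1ccccc1CNc1cccc2[nH]ncc12` is the weaker of the two compounds measured so far. In an assay for inhibition of Tryptophan 2,3-dioxygenase (Homo sapiens), with stated times of 10 min and 60 min, tested at 10 uM (a lower number here means a weaker effect, a higher number a stronger effect of the compound at the concentration tested), compound 1 gives 45%. Compound 2 `O=[N+]([O-])c1cc(Cl)ccc1CNc1cc(C(F)(F)F)cc2[nH]ncc12` carries a chloro and a trifluoromethyl group that compound 1 lacks. In this assay compound 2 gives a value of 90%, a number that lies well beyond the usual scatter above that of compound 1.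

Compound 3 `O=[N+]([O-])c1ccccc1CNc1cc(Br)cc2[nH]ncc12` is not yet measured. It differs from compound 1 in a single place: bromo in place of hydrogen on an aromatic carbon. Within the data shown here, no step between two measured compounds isolates this single change, so the expectation rests on the higher value of compound 2 alone. A moderate rise in this assay is expected, on the order of a number 20 percentage points higher from compound 1 to compound 3 (beyond the scatter), with a wide uncertainty. Compound 3 is therefore estimated at 65%, within a range from 40% to 85%.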

Compound 3, a percentage reported as inhibition, at one concentration (the size of the read-out at that concentration, not a potency): 52%
Compound 3: the middle estimate sits 13 percentage points above what was measured, and the stated range covers the measured number.
By their numbers in this assay, from the lowest: compounds 1 and 3 (each within the scatter of the next); then compound 2.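

In this assay, within the data shown here, bromo in place of hydrogen on this aromatic carbon, para to a fused ring, gives a step of a number 7 percentage points higher from compound 1 to compound 3 (within the scatter) and is the first change in a single place that can be read here. Compound 1 and compound 3 therefore cannot be told apart in this assay, so a bromo at this position does not by itself separate them at the concentration tested. No other measurement shown here bears on this result.

The compounds shown leave open how an amine or a carboxylic acid on this same carbon would read. They also leave open what the chloro and the trifluoromethyl group each contribute on their own, as these two groups appear only together, in compound 2.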